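The source may hold more compounds than are shown below. What is called first, only, known or untested is meant among the compounds shown, and "the series" means these compounds.

Measured so far: compound 2 `COc1cc(-c2nn(-c3cccc(NC(=O)Nc4cc(C(F)(F)F)cc(C(F)(F)F)c4)c3)cc2-c2ccncc2)ccc1Cl` at 931 nM; compound 1 `O=C(Nc1cccc(-n2cc(-c3ccncc3)c(-c3ccc(Cl)c(O)c3)n2)c1)Nc1cccc(C(F)(F)F)c1` at 7260 nM.

In a functional assay on HCC 2998 cells (Homo sapiens) for inhibition, read by sulforhodamine B assay, with a stated time of 48 h (on this read-out higher numbers stand for weaker inhibition of growth and lower numbers for stronger inhibition of growth), compound 2 gives the lower of the two numbers, and compound 1 stands a gap beyond the scatter above it. Compound 3 `O=C(Nc1cccc(-n2cc(-c3ccncc3)c(-c3ccc(Cl)c(O)c3)n2)c1)Nc1cc(C(F)(F)F)cc(C(F)(F)F)c1` differs from compound 2 by hydrogen in place of methyl on an oxygen on an aromatic ring. Among the measured compounds shown here, no measured pair shows this change on its own. Compound 1 carries the same hydroxy group and gives 7260 nM, a weaker result. A step toward a higher number is therefore expected, of moderate size, a 2.7-fold higher number from compound 2 to compound 3 (0.43 log units; beyond the scatter). Compound 3 is estimated at 2500 nM, with a range from 900 nM to 8000 nM.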

Compound 3, concentration for 50% growth inhibition: 1030 nM
For compound 3 the middle estimate is 2.4-fold (0.39 log units) above the measured one; low and high end bracket the measured number.
By their numbers in this assay, from the lowest: compounds 2 and 3 (each within the scatter of the next); then compound 1.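

In this assay, methoxy to hydroxy on the aromatic oxygen gives (a 1.1-fold higher number from compound 2 to compound 3 (0.04 log units; within the scatter)), so at this position the oxygen tolerates either group when the second aromatic ring carries both trifluoromethyl groups. Trifluoromethyl in place of hydrogen on an aromatic carbon gives (a 7.0-fold lower number from compound 1 to compound 3 (0.85 log units; beyond the scatter)), the only step here beyond the scatter, and it shows that the weak number of compound 1 does not go with the hydroxy group alone. No measured evidence explains either step.

As far as these compounds go, whether an ethoxy group or an amine in place of hydroxy at this position would hold the same level remains open. So does whether methoxy and hydroxy would also stay level with hydrogen in place of that trifluoromethyl.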